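A Fluorine Added to the Phenoxy Arm

This account rests on a few compounds, and the source may have more. Where it says the series, first, only, none or still open, it means among the compounds named here.

Of the compounds shown here, three built on a shared core have been tested in a physicochemical assay for solubility, read by spectrophotometry, in phosphate buffer, with a stated time of 2 h, at pH 7.4; a lower number here means a less soluble compound, a higher number a more soluble compound. Compound 1 `COc1cccc(CN2C(=O)CN(C(=O)c3cc4cc(OC)ccc4o3)C[C@@H]2CCc2ccccc2)c1` gives 4900 nM. Compound 2 `COc1ccc2[nH]c(C(=O)N3CC(=O)N(Cc4ccccc4)[C@@H](COc4ccccc4)C3)cc2c1` gives 12200 nM. Compound 3 `COc1ccc2[nH]c(C(=O)N3CC(=O)N(Cc4ccccc4)[C@@H](CN4CCN(S(=O)(=O)c5ccccc5)CC4)C3)cc2c1` gives 16900 nM. Among these three numbers compound 2 stands second highest: its nearest neighbour is compound 3, whose value lies within the usual scatter of such measurements, so the two cannot be told apart; its furthest neighbour is compound 1, whose value lies beyond the scatter and is clearly the lower of the pair.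

Compound 4 `COc1ccc2[nH]c(C(=O)N3CC(=O)N(Cc4ccccc4)[C@@H](COc4ccc(F)cc4)C3)cc2c1` has not yet been measured in this assay. It is made from compound 2 by one change: fluoro in place of hydrogen on an aromatic carbon. Going by the values given here, no measured pair in this set shows what such a change does to solubility, so the expectation rests on the closeness of the two structures alone. The step from compound 2 to compound 4 is expected to be small, a 1.4-fold lower number from compound 2 to compound 4 (0.13 log units; within the scatter), leaning slightly toward a lower number but not beyond the scatter. On that basis compound 4 is estimated at 9000 nM, with a plausible range from 4000 nM to 20000 nM.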

Compound 4, solubility: 17500 nM
Beside the measured number, compound 4's estimate is 1.9-fold (0.29 log units) below it; the range from low to high includes it.
By their numbers in this assay, from the lowest: compound 1; then compounds 2, 3 and 4 (each within the scatter of the next).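

In this assay, going by these compounds alone, this is the first pair in the set that differs in one place, and it reads as a 1.4-fold higher number from compound 2 to compound 4 (0.16 log units; within the scatter) and no more. Fluoro in place of hydrogen on this aromatic carbon, para to a large group, therefore produces no difference that can be separated from the ordinary spread of repeat measurements. The earlier compounds shown here could not show this, since each differed from the others in more than one place, whereas here the phenoxy arm can be read on its own, and going from phenoxy to 4-fluorophenoxy leaves the two compounds indistinguishable in this assay. No measured property is at hand that would explain this reading.

This single step says nothing yet about what a different group on the same carbon, such as methoxy, trifluoromethyl or an amine, would do to the number. It also leaves open whether fluoro on another carbon of the same ring would likewise stay within the scatter, or whether the same change would read alike on a different arm of the shared core.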